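The source may report more compounds than this note shows. Statements on the series, on what has been measured and on what is new or still open speak of the compounds shown alone.

In a functional assay on A549 cells (Homo sapiens) for antiproliferative activity, read by MTT assay, with a stated time of 48 h (a higher number here means a weaker inhibitor, a lower number a stronger inhibitor), three compounds that differ at one place on a shared core have been measured. Compound 1 `Fc1ccc2[nH]c(-c3cn(-c4ccccc4)nc3-c3ccc(Cl)cc3)nc2c1`, carrying fluoro, gives 4610 nM. Compound 3 `O=C(OCc1ccccc1)c1ccc2[nH]c(-c3cn(-c4ccccc4)nc3-c3ccc(Cl)cc3)nc2c1`, carrying benzyloxycarbonyl, gives 7730 nM, and a 1.7-fold higher number from compound 1 to compound 3 (0.22 log units; within the scatter) stays within the scatter. Compound 2 `Clc1ccc(-c2nn(-c3ccccc3)cc2-c2nc3cc(Br)ccc3[nH]2)cc1`, carrying bromo, gives 2170 nM, the lowest number of the three. It stands apart through two modest steps: a 2.1-fold lower number from compound 1 to compound 2 (0.33 log units; beyond the scatter) and a 3.6-fold higher number from compound 2 to compound 3 (0.55 log units; beyond the scatter).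

Compound 4 `COc1ccc(-c2nn(-c3ccccc3)cc2-c2nc3cc(Br)ccc3[nH]2)cc1` keeps the bromo and changes 4-chlorophenyl to 4-methoxyphenyl, with methoxy in place of chloro on an aromatic carbon. Among the compounds with values here, none of the measured steps touches this place, so they offer only a rough guide to size and no direction. A small rise is expected as a cautious guess, since compound 2 already sits lowest at 2170 nM. The estimated step is a 1.4-fold higher number from compound 2 to compound 4 (0.14 log units; within the scatter), which is not expected to go beyond the scatter. Compound 4 is estimated at 3000 nM, with an expected range from 1100 nM to 8000 nM.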

Compound 4, half-maximal inhibitory concentration: 6370 nM
Estimate against measurement, compound 4: 2.1-fold (0.33 log units) below; the range from low to high includes it.
By their numbers in this assay, from the lowest: compound 2; then compounds 1, 4 and 3 (each within the scatter of the next).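

Changing this second place on the shared core, in this assay, gives a 2.9-fold higher number from compound 2 to compound 4 (0.47 log units; beyond the scatter) with methoxy in place of chloro on the aromatic carbon para to a large group. The number therefore responds to a change at this place as well as to the change of bromo, fluoro or benzyloxycarbonyl at the other place, and among the two groups seen here, chloro goes with the lower number. Nothing available explains why this swap raises the number.

Only chloro and methoxy are shown at this place, so it remains open how a hydroxyl, an amine or a longer chain such as ethoxy would behave there. The step is also read only with bromo on the core, leaving open whether it would hold with fluoro or benzyloxycarbonyl.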